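Swapping diethylamino for dipropylamino on the side chain

A few compounds are considered here, and "the series" means these few. Any claim that something is new, unique, unknown or untested is made for them only; others in the source may bear on it.

In a functional assay on LNCaP cells (Homo sapiens) for antiproliferative activity, read by WST assay, with a stated time of 3 days (a lower number here means a stronger inhibitor, a higher number a weaker inhibitor), compound 3 `CCN(CC)CCCCCOc1c(-c2cc(OC)c(OC)c(OC)c2)oc2ccccc2c1=O` gives 10000 nM as its reading. Compound 1 `CCC(C)Oc1c(-c2cc(OC)c(OC)c(OC)c2)oc2ccccc2c1=O` gives 9300 nM as its reading, and the change of a 1.1-fold higher number from compound 1 to compound 3 (0.03 log units; within the scatter) means these two cannot be told apart. Compound 2 `CCN(CC)CCCOc1c(-c2cc(OC)c(OC)c(OC)c2)oc2ccccc2c1=O` is the weakest of the three, with 37600 nM as its reading.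

In compound 4 `CCCN(CCC)CCCCOc1c(-c2cc(OC)c(OC)c(OC)c2)oc2ccccc2c1=O`, dipropylamino stands in place of (diethylamino)methyl on a saturated chain carbon, four bonds along the chain from an oxygen on an aromatic ring dipropylamino in place of (diethylamino)methyl on a saturated chain carbon, four bonds along the chain from an oxygen on an aromatic ring in the structural count. Going by the values given here, no measured pair shows this exact change. The closest guide is the modest 3.8-fold lower number from compound 2 to compound 3 (0.58 log units; beyond the scatter) seen between two chain lengths, and the chain of compound 4 is longer than that of compound 2 but shorter than that of compound 3. A small drift towards weaker activity therefore seems plausible. The expected change is a 1.4-fold higher number from compound 3 to compound 4 (0.15 log units; within the scatter) in this assay as an estimate, so no clear step is foreseen. Compound 4 is estimated at 14000 nM with 5000 nM to 40000 nM as the expected range.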

Compound 4, half-maximal inhibitory concentration: 16800 nM
The estimate for compound 4 lay 1.2-fold (0.08 log units) below the measured number; the measured number falls inside the stated range.
By their numbers in this assay, from the lowest: compounds 1, 3 and 4 (each within the scatter of the next); then compound 2.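

In this assay, putting dipropylamino in place of (diethylamino)methyl, on a saturated chain carbon four bonds along the chain from an oxygen on an aromatic ring, gives a 1.7-fold higher number from compound 3 to compound 4 (0.23 log units; within the scatter) and so no real change in the reading. Going by these compounds alone, the 4-(dipropylamino)butyl chain also cannot be told apart from sec-butyl, with a 1.8-fold higher number from compound 1 to compound 4 (0.26 log units; within the scatter) as the step, yet it does separate from the 3-(diethylamino)propyl chain, with a 2.2-fold lower number from compound 2 to compound 4 (0.35 log units; beyond the scatter) as a modest gain, so compound 2 remains the one clearly weaker reading. Nothing measured here accounts for these differences.

Also open, from the compounds shown here alone, is what dipropylamino does on its own, as the amine and the chain length change together in compound 4. A ring amine such as piperidine or morpholine on the same chain remains an untested kind of change in this set.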